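From 4-chlorophenyl to 2-chlorophenyl with diethylamino

The compounds below may be only part of what the source reports. "The series", "measured", "known", "first", "only" and "open" are said of these compounds alone.

Of the compounds shown here, three have been measured in a functional assay on A549 cells (Homo sapiens) for cytotoxicity, read by MTT assay, with a stated time of 72 h (a higher number here means a weaker inhibitor, a lower number a stronger inhibitor), so far.

Compound 1 `CCN(CC)Cc1ccc2nc(NC(=O)N/N=C/c3cn(Cc4cccc(Cl)c4)c4ccccc34)sc2c1` gives 2410 nM
Compound 2 `CCN(CC)Cc1ccc2nc(NC(=O)N/N=C/c3cn(Cc4ccc(Cl)cc4)c4ccccc34)sc2c1` gives 2940 nM
Compound 3 `CN(C)Cc1ccc2nc(NC(=O)N/N=C/c3cn(Cc4ccc(Cl)cc4)c4ccccc34)sc2c1` gives 840 nM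

Compound 2 sits at the high end of these numbers, level with compound 1 within the scatter and clearly apart from compound 3. Compound 4 `CCN(CC)Cc1ccc2nc(NC(=O)N/N=C/c3cn(Cc4ccccc4Cl)c4ccccc34)sc2c1` differs from compound 2 by 2-chlorophenyl in place of 4-chlorophenyl on a saturated chain carbon bound to an aromatic nitrogen with 2-chlorophenyl in place of 4-chlorophenyl on a saturated chain carbon bound to an aromatic nitrogen. Among the compounds with values here, the only comparable change is a 1.2-fold higher number from compound 1 to compound 2 (0.09 log units; within the scatter) for 4-chlorophenyl in place of 3-chlorophenyl. The other step, a 3.5-fold lower number from compound 2 to compound 3 (0.54 log units; beyond the scatter) in the amine, concerns a different place and does not bear on this change. Within the data shown here, no measured compound carries 2-chlorophenyl, so the comparison remains indirect. The estimated step is a 1.1-fold lower number from compound 2 to compound 4 (0.05 log units; within the scatter) and none beyond the scatter is expected in this assay for this change. For compound 4 the estimate is 2600 nM with 1200 nM to 5500 nM as its expected range.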

Compound 4, half-maximal inhibitory concentration: 1390 nM
Compound 4: middle estimate off by 1.9-fold (0.27 log units), on the high side; the range from low to high includes it.
By their numbers in this assay, from the lowest: compounds 3, 4, 1 and 2 (each within the scatter of the next, the first and the last beyond it).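

On the saturated chain carbon bound to an aromatic nitrogen, the choice of chlorophenyl now registers in this assay as a 2.1-fold lower number from compound 2 to compound 4 (0.33 log units; beyond the scatter) is a modest step beyond the scatter, whereas the earlier exchange of chlorophenyl groups stayed within it. This does not set 2-chlorophenyl apart from both other chlorophenyl groups, since a 1.7-fold lower number from compound 1 to compound 4 (0.24 log units; within the scatter) also lies within the scatter. No evidence at hand accounts for the difference.

From the compounds shown here alone, whether this step carries over to the dimethylamino series stays open, as does what an unsubstituted phenyl or a 2-methoxyphenyl would give at this place.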